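Swapping the ring on the core of compound 1

The source may report more compounds than this note shows. Statements on the series, on what has been measured and on what is new or still open speak of the compounds shown alone.

Compound 1, `CC(=O)N1CCC(c2ccc3c(c2)oc(=O)n3C(=O)NCCCCc2ccccc2)CC1`: 64 nM
Compound 2, `O=C(NCCCCc1ccccc1)n1c2c(oc1=O)CNCC2`: 340 nM

Of the compounds shown here, two have been measured in an assay on HEK293 cells for inhibition of acid ceramidase (Homo sapiens), read by fluorescence, with stated times of 10 min and 3 h; on this read-out lower numbers stand for stronger inhibition and higher numbers for weaker inhibition. Compound 1 gives 64 nM, the lower of the two numbers. Compound 2, built on a different core, gives 340 nM; the gap between compound 1 and compound 2 lies beyond the scatter, so compound 1 stands as the stronger inhibitor of the two in this assay.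

Compound 3, `CN1CCN(c2ccc3c(c2)oc(=O)n3C(=O)NCCCCc2ccccc2)CC1`, has not been measured. It differs from compound 1 in one place: 4-methylpiperazin-1-yl in place of 1-acetylpiperidin-4-yl on an aromatic carbon. Both groups are saturated six-membered rings carried on the same aromatic carbon of the shared core, so the shape of the molecule changes little, while the counted acceptors differ as shown.

For the measured compounds named here, no measured pair shows what such a change does in this assay. Compound 3 is therefore expected to stay close to compound 1, with a step of a 1.6-fold higher number from compound 1 to compound 3 (0.19 log units; within the scatter), and its number is estimated at 100 nM, within a range of 30 nM to 350 nM.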

Compound 3, half-maximal inhibitory concentration: 116 nM
For compound 3 the middle estimate is 1.2-fold (0.06 log units) below the measured one; the measured number falls inside the stated range.
By their numbers in this assay, from the lowest: compounds 1 and 3 (each within the scatter of the next); then compound 2.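

For the compounds shown here, on the aromatic carbon of the shared core, putting 4-methylpiperazin-1-yl in place of 1-acetylpiperidin-4-yl gives in this assay a 1.8-fold higher number from compound 1 to compound 3 (0.26 log units; within the scatter) and so provides the first pair that speaks to this position. The two groups differ in their ring hetero atoms, in the double bond outside aromatic rings that only 1-acetylpiperidin-4-yl carries, and in their counted hydrogen-bond acceptors, yet together these differences leave the two compounds within the scatter of each other. No measurement at hand accounts for this result.

The pair changes the ring and its substituent at once, so it leaves open what each contributes alone, which 4-acetylpiperazin-1-yl on the same aromatic carbon would separate. It also leaves open whether this position would accept a group without a six-membered non-aromatic ring, such as a simple amine, a carboxylic acid or a longer chain.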